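Adding an Aroylamino Group to Compound 2

This account rests on a few compounds, and the source may have more. Where it says the series, first, only, none or still open, it means among the compounds named here.

Measured in a functional assay on PG cells (Homo sapiens) for cytotoxicity, read by MTT assay, with a stated time of 48 h; on this read-out lower numbers stand for an effect already at smaller amounts and higher numbers for an effect only at larger amounts of compound:
- Compound 1 `CC(=O)O[C@@H]1[C@@H](OC(C)=O)[C@@H](O)CO[C@H]1NC(=S)NNC(=O)Cn1cnc2c(N)ncnc21`: > 200000 nM, a limit
- Compound 2 `CC(=O)O[C@@H]1[C@@H](OC(C)=O)[C@@H](O)CO[C@H]1NC(=S)NNC(=O)Cn1cnc2ccccc21`: > 200000 nM, a limit
- Compound 3 `COc1ccc(C(=O)Nc2nc3ccccc3n2CC(=O)NNC(=S)N[C@@H]2OC[C@H](O)[C@H](OC(C)=O)[C@H]2OC(C)=O)cc1`: not yet measured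

Compound 2 gives > 200000 nM, which is a limit and not a number. Compound 3 carries ((4-methoxyphenyl)carbonyl)amino in place of hydrogen on an aromatic carbon. Among the measured compounds shown here, the only measured step, a step that the two limits leave unreadable from compound 1 to compound 2, exchanges a different group and gives no size to carry over. The record so far is the limit of > 200000 nM in this assay, at which 2 of the 2 values shown sit. For the measured compounds named here, no measured step therefore speaks directly to this change. Since compound 2 sits at > 200000 nM a readable result in this assay could only lie towards smaller amounts, and a modest move of that kind is expected, though another limit remains quite possible. The expected change is an at least 1.6-fold lower number from compound 2 to compound 3 (0.22 log units; that floor lies within the scatter). For compound 3 the estimated value is 120000 nM, with an expected range of 30000 nM to 200000 nM.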

Compound 3, half-maximal effective concentration: 73700 nM
Compound 3: middle estimate off by 1.6-fold (0.21 log units), on the high side; the measured number falls inside the stated range.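

In this assay, among the compounds shown here, ((4-methoxyphenyl)carbonyl)amino in place of hydrogen on an aromatic carbon gives an at least 2.7-fold lower number from compound 2 to compound 3 (0.43 log units; beyond the scatter), the first step here whose direction can be read, as the step between the two earlier compounds cannot. It shows that this place, between two ring nitrogen atoms, accepts a group of this size with a lower number as the result, although that number still marks an effect only at large amounts. Compound 3 is also the only compound shown with a value that is not a limit: the limit of > 200000 nM in this assay, at which 2 of the 3 values shown sit.

The compounds shown do not tell whether a plain amine or an acetylamino group at this place would also lower the number, or what part the methoxy group plays. From the compounds shown here alone, whether the same group would act alike on the core of compound 1 also stays open.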